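Hydroxyphenyl pyridines: ring swap at the core, compound 3

The compounds below may be only part of what the source reports. "The series", "measured", "known", "first", "only" and "open" are said of these compounds alone.

Measured so far:
compound 1, `Oc1ccc(-c2cc(-c3ccco3)cc(-c3cccc(O)c3)n2)cc1`, 1280 nM
compound 2, `Oc1cccc(-c2cc(-c3ccccn3)cc(-c3cccc(O)c3)n2)c1`, 1410 nM

In a functional assay on T47D cells (Homo sapiens) for cytotoxicity, read by CCK-8 assay (on this read-out lower numbers stand for stronger inhibition and higher numbers for weaker inhibition), compound 2 gives 1410 nM, the higher of the two numbers in hand, but its nearest neighbour, compound 1 with 1280 nM, lies within the scatter, so the two cannot be told apart. For the measured compounds named here, no pair of measured compounds differs in a single place, so no step size is known from direct comparison.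

Compound 3, `Oc1ccc(-c2cc(-c3ccccn3)cc(-c3cccc(O)c3)n2)cc1`, has not been measured. It differs from compound 2 by 4-hydroxyphenyl in place of 3-hydroxyphenyl on an aromatic carbon. Both measured compounds carry a hydroxyphenyl group at this position of the shared core, one with the hydroxyl in the 3-position and one in the 4-position, and the two numbers sit close together. The expected step from compound 2 to compound 3 is therefore a 1.0-fold lower number from compound 2 to compound 3 (0.00 log units; within the scatter), that is, none beyond the scatter. Compound 3 is estimated at 1400 nM, with a range from 600 nM to 3500 nM.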

Compound 3, half-maximal inhibitory concentration: 980 nM
Compound 3: middle estimate off by 1.4-fold (0.15 log units), on the high side, and the stated range covers the measured number.
By their numbers in this assay, from the lowest: compounds 3, 1 and 2 (each within the scatter of the next).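

In this assay the first direct read at this position, next to the ring nitrogen, is a 1.4-fold lower number from compound 2 to compound 3 (0.16 log units; within the scatter), so 4-hydroxyphenyl and 3-hydroxyphenyl cannot be told apart here. The second single change, pyridin-2-yl in place of furan-2-yl on an aromatic carbon, gives a 1.3-fold lower number from compound 1 to compound 3 (0.12 log units; within the scatter), and so it also stays inside the scatter. Both changes can now be read directly, though no independent data on these groups accompany the numbers.

As far as these compounds go, what an amine, a methoxy group or a carboxylic acid in place of the hydroxyl would do at this position remains open. Also open, from the compounds shown here alone, is whether any single change on the shared core can move the number beyond the scatter.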